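This account rests on a few compounds, and the source may have more. Where it says the series, first, only, none or still open, it means among the compounds named here.

Of the compounds shown here, three sharing one core have been measured in a functional assay on MDA-MB-231 cells (Homo sapiens) for cytotoxicity, read by MTT assay, with a stated time of 24 h (a lower number here means a stronger inhibitor, a higher number a weaker inhibitor), but no two of them differ in one place only. Compound 2 (`CCNC(=O)c1ccc(-c2nc3cccnc3n2C2CCCC2)cc1`) gives 320 nM in this assay and stands within the scatter of compound 3 (`c1ccc(Cn2nccc2-c2nc3cccnc3n2C2CCCC2)cc1`), which gives 348 nM there. Compound 1 (`Fc1cc(F)cc(-c2nc3cccnc3n2C2CCCC2)c1`) shows a lower number, 138 nM in the same test, and its gap to compound 2 lies beyond the scatter.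

Compound 4 (`c1cncc(-c2ccc(-c3nc4cccnc4n3C3CCCC3)cc2)c1`) has not yet been measured. It keeps the core of compound 2 and carries pyridin-3-yl in place of ethylcarbamoyl on an aromatic carbon, para to a large group. Among the compounds with values here, no measured pair shows this exchange, so the data offer no direct guide to its effect. The expectation rests only on the modest spread among the measured compounds, from compound 1 at 138 nM to compound 3 at 348 nM in the same test. No shift beyond the scatter is expected in this assay, and the estimated change, a 1.1-fold lower number from compound 2 to compound 4 (0.06 log units; within the scatter) as a small step, leans slightly towards a lower number. For compound 4 the estimated value is 280 nM with 110 nM as the lower end and 700 nM as the upper end of the expected range.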

Compound 4, half-maximal inhibitory concentration: > 10000 nM
Compound 4: only a limit was reported; the forecaster's own chance of this, stated with the estimate: 3%; middle value at least 35-fold (1.55 log units) away from the limit.
By their numbers in this assay, from the lowest: compound 1; then compounds 2 and 3 (each within the scatter of the next). At a limit, above all of these: compound 4.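

Within the data shown here, replacing ethylcarbamoyl with pyridin-3-yl on this aromatic carbon, para to a large group, gives an at least 31-fold higher number from compound 2 to compound 4 (1.49 log units; beyond the scatter) in this assay, so this position is far from indifferent to what it carries, something the earlier compounds, with no pair differing in one place, could not show. Compound 4 stands at a limit of the assay, so this step gives a least size and not a full one: the limit of > 10000 nM in this assay, at which 1 of the 4 values shown sits. The group that leaves holds a hydrogen-bond donor and no ring, whereas the group that enters holds no donor and a six-membered aromatic ring, but this single pair cannot tell which of these differences goes with the step.

The compounds shown leave open whether the step follows the loss of the amide or the arrival of the pyridine ring, a question that a plain phenyl, a pyridin-4-yl, a methylcarbamoyl or a carboxylic acid on the same carbon would help to settle. They also leave open whether the same exchange acts alike when the rest of the molecule is changed.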